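Bromo in place of trifluoromethyl: cytotoxicity outlook

A few compounds are considered here, and "the series" means these few. Any claim that something is new, unique, unknown or untested is made for them only; others in the source may bear on it.

Compound 2 `CC(C)N(Cc1cccc(OCCCCCC(=O)O)c1)C(=O)c1ccc(-c2cccc(C(F)(F)F)c2)cc1` has been measured in an ADME assay on Raji cells (Homo sapiens) for cytotoxicity, read by CellTiter-Glo and resazurin assay, with a stated time of 72 h; a lower number here means that less compound is needed, a higher number that more compound is needed for the effect. In this assay compound 2 gives > 26000 nM, which is a limit of the assay and not a number. Compound 1 `CC(=O)Nc1cccc(-c2ccc(C(=O)N(Cc3cccc(OCCCCCC(=O)O)c3)C(C)C)cc2)c1` gives in this assay > 26000 nM, likewise a limit only. The step that the two limits leave unreadable from compound 1 to compound 2 cannot be read: see (the limit of > 26000 nM in this assay, at which 2 of the 2 values shown sit). Compound 3 `CC(C)N(Cc1cccc(OCCCCCC(=O)O)c1)C(=O)c1ccc(-c2cccc(Br)c2)cc1` is not yet measured in this assay; it differs from compound 2 by bromo in place of trifluoromethyl on an aromatic carbon. Among the compounds with values here, the only measured step concerns a different group and yields no size, so it supports no direction for the new change; the two measured values simply show both compounds at the limit. On this basis compound 3 is expected at about 30000 nM, within 8000 nM to 100000 nM, most likely reported again as a limit rather than a number. The expected step that the limit leaves unreadable from compound 2 to compound 3 is accordingly estimated as none beyond the scatter.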

Compound 3, half-maximal effective concentration: > 26000 nM
Compound 3: only a limit was reported (the forecaster's own chance of this, stated with the estimate: 80%); the middle value is on the limit's open side.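

In this assay no step can be read among compound 1, compound 2 and compound 3, because all three remain at the limit: (the limit of > 26000 nM in this assay, at which 3 of the 3 values shown sit). The compounds shown leave open how the acetamido, trifluoromethyl and bromo compounds would rank if their values could be read as numbers.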